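Adding a methyl to the ring nitrogen of compound 1

The compounds below may be only part of what the source reports. "The series", "measured", "known", "first", "only" and "open" are said of these compounds alone.

Compound 1 `O=C(Nc1ccc(Oc2ccnc3[nH]ccc23)cc1)c1nn(-c2ccc(Cl)cc2)ccc1=O` is one of two compounds measured in a functional assay on HepG2 cells (Homo sapiens) for cytotoxicity, read by MTT assay, with a stated time of 72 h (on this read-out higher numbers stand for weaker inhibition and lower numbers for stronger inhibition), where compound 1 gives 19500 nM, the highest of the two numbers shown. Among the measured compounds shown here, the other, compound 2 `O=C(Nc1ccc(Oc2ccnc3[nH]ccc23)cc1)c1nn(-c2ccc(Cl)c(F)c2)ccc1=O`, differs only by a fluoro in place of hydrogen on an aromatic carbon, and in this assay compound 2 gives 5240 nM; the step of a 3.7-fold lower number from compound 1 to compound 2 (0.57 log units; beyond the scatter) is the only measured comparison available.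

The change of interest leads to compound 3 `Cn1ccc2c(Oc3ccc(NC(=O)c4nn(-c5ccc(Cl)cc5)ccc4=O)cc3)ccnc21`, which differs from compound 1 by methyl in place of hydrogen on an aromatic nitrogen. For the measured compounds named here, this is a change at a different place from the one seen between compound 1 and compound 2, so that step does not bear on it directly, and nothing else here shows what a methyl at this position does. With no guiding comparison, the expected outcome is a step from compound 1 to compound 3 of a 1.3-fold higher number from compound 1 to compound 3 (0.11 log units; within the scatter), that is, no clear shift beyond the usual scatter, with a wide band of uncertainty. On that basis compound 3 is estimated at 25000 nM, within a range from 8000 nM to 80000 nM.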

Compound 3, half-maximal inhibitory concentration: > 60000 nM
Compound 3 was reported as a limit; the forecaster's own chance of this, stated with the estimate: 15%; middle value at least 2.4-fold (0.38 log units) from the limit.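

With methyl in place of hydrogen on an aromatic nitrogen of the five-membered aromatic ring, the number in this assay rises, with a step of an at least 3.0-fold higher number from compound 1 to compound 3 (0.48 log units; beyond the scatter). Among the compounds shown here, this shows that the position is not indifferent to change, which compound 1 and compound 2 could not show, since their only step, a 3.7-fold lower number from compound 1 to compound 2 (0.57 log units; beyond the scatter), lies at a different place and runs towards a lower number, while this single added carbon moves the read-out towards weaker inhibition. Compound 3 is given only as a limit of the assay, > 60000 nM, not as a measured number, so the direction of the step is clear while its true size is not, and the reading rests on that limit: the limit of > 60000 nM in this assay, at which 1 of the 3 values shown sits.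

The compounds shown leave open whether any group on this nitrogen gives the same outcome, or whether an ethyl, a longer chain or a chain ending in an amine would behave differently from methyl. They also leave open what methyl at this position does when the fluoro of compound 2 is present, and they give no cause for the step.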